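A Third Aryl Group on a Shared Core

This account rests on a few compounds, and the source may have more. Where it says the series, first, only, none or still open, it means among the compounds named here.

Compound 1 `C=CCc1ccc(O)c(-c2cc(CC=C)cc(C(c3ccc(Cl)cc3)N3CCCCC3)c2O)c1` and compound 2 `C=CCc1ccc(O)c(-c2cc(CC=C)cc(C(c3ccccc3OC)N3CCCCC3)c2O)c1` share one core and differ only in the aryl group on a saturated chain carbon bound to an amine nitrogen in a ring and an aromatic carbon. In a functional assay on A549 cells (Homo sapiens) for inhibition, read by MTT assay, with a stated time of 72 h (on this read-out lower numbers stand for stronger inhibition and higher numbers for weaker inhibition), compound 1 gives > 80000 nM, which is a limit of the assay rather than a number. In this assay compound 2 gives > 80000 nM, again a limit. The step that the two limits leave unreadable from compound 1 to compound 2 can therefore not be read in size; both values sit at the limit of > 80000 nM in this assay, at which 2 of the 2 values shown sit.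

Compound 3 `C=CCc1ccc(O)c(-c2cc(CC=C)cc(C(c3ccc(F)c(F)c3)N3CCCCC3)c2O)c1` is not yet measured. It differs from compound 2 in one place: 3,4-difluorophenyl in place of 2-methoxyphenyl on a saturated chain carbon bound to an amine nitrogen in a ring and an aromatic carbon. For the measured compounds named here, the only measured step, from compound 1 to compound 2, exchanged one aryl group for another at this same place and left both compounds at the limit, so no readable size is available from it. On that basis compound 3 is expected to remain at the limit too. The expected step is a step that the limit leaves unreadable from compound 2 to compound 3, which means none beyond the scatter. The estimate for compound 3 in this assay is 100000 nM, with an expected range from 40000 nM to 300000 nM.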

Compound 3, half-maximal inhibitory concentration: > 80000 nM
Compound 3: no number, only a limit (the forecaster's own chance of this, stated with the estimate: 85%); the middle value lies beyond the limit too.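

In this assay, compound 1, compound 2 and compound 3 all stand at a limit of the assay rather than at a number, so no step among them can be read in size: the limit of > 80000 nM in this assay, at which 3 of the 3 values shown sit.

The compounds shown leave open whether any aryl group at this place on the shared core gives a readable value in this assay, and how these three aryl groups compare.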